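Working notes: removing the chain from compound 2

The source may report more compounds than this note shows. Statements on the series, on what has been measured and on what is new or still open speak of the compounds shown alone.

Compound 1 `COc1ccc(N(C)c2nc(C)nc3ccccc23)cc1OCCCCCC[Se]C#N`: 4890 nM
Compound 2 `COc1ccc(N(C)c2nc(C)nc3ccccc23)cc1OCCCC[Se]C#N`: 6460 nM

In a functional assay on HepG2 cells (Homo sapiens) for inhibition, read by MTT assay, with a stated time of 48 h (a lower number here means a stronger inhibitor, a higher number a weaker inhibitor), compound 2, at 6460 nM, lies within the scatter of compound 1. Compound 3 `COc1ccc(N(C)c2nc(C)nc3ccccc23)cc1[Se]C#N` carries this change: a group of 3 heavy atoms (1 carbon, 1 nitrogen, 1 selenium; no ring) in place of a group of 8 heavy atoms (5 carbon, 1 nitrogen, 1 oxygen, 1 selenium; no ring), on an aromatic carbon. It sits on an aromatic carbon, ortho to a methoxy group. Within the data shown here, the only measured step, a 1.3-fold higher number from compound 1 to compound 2 (0.12 log units; within the scatter), is within the scatter and bears only partly, since it leaves the ring oxygen in place. Among the measured compounds shown here, no measured compound lacks that oxygen, so the direction is weakly held. The expected step is a 2.6-fold lower number from compound 2 to compound 3 (0.41 log units; beyond the scatter). For compound 3 the estimated value is 2500 nM, with an expected range of 400 nM to 12000 nM.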

Compound 3, half-maximal inhibitory concentration: 59 nM
Estimate against measurement, compound 3: 42-fold (1.63 log units) above, and the stated range ends above it.
By their numbers in this assay, from the lowest: compound 3; then compounds 1 and 2 (each within the scatter of the next).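

In this assay, taking the chain off together with its ring oxygen, so that the group of 3 heavy atoms sits directly on the aromatic carbon, gives a 110-fold lower number from compound 2 to compound 3 (2.04 log units; beyond the scatter) and an 83-fold lower number from compound 1 to compound 3 (1.92 log units; beyond the scatter). The two chain-bearing compounds gave no sign of this sensitivity, so the position responds strongly to this change, though not to the chain shortening between them. Nothing available explains the size of these steps.

Still open, going by these compounds, is whether the ring oxygen or the chain accounts for the steps, as both leave together. A shorter chain on that oxygen would separate them, while a nitrile or an amine on the same aromatic carbon would test whether the selenium is needed.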